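The compounds below may be only part of what the source reports. "The series", "measured", "known", "first", "only" and "open" are said of these compounds alone.

Working notes on the series. Of the compounds shown here, three sharing a common core have been measured in an assay on isolated protein for binding affinity to B1 bradykinin receptor (Homo sapiens); on this read-out lower numbers stand for stronger inhibition and higher numbers for weaker inhibition. Compound 1, `COC(=O)c1ccccc1N1CCC(C)(CNc2nccc(C)c2NC(=O)CC#N)CC1`, gives 3500 nM. Compound 2, `COC(=O)c1cccn1-c1ccc(CNc2nccc(C)c2NC(=O)CC#N)cc1`, gives 250 nM. Compound 3, `COC(=O)C1C2CCC(CC2)C1c1ccc(CNc2nccc(C)c2NC(=O)CC#N)cc1`, gives 54 nM. Among these three numbers compound 2 holds the second highest: the gap to compound 3, its nearest neighbour, lies beyond the usual scatter, as does the larger gap to compound 1, which is the furthest from it.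

Compound 4, `COC(=O)C1=C(c2ccc(CNc3nccc(C)c3NC(=O)CC#N)cc2)CCC1`, has not yet been measured in this assay. It differs from compound 2 in one place: 2-(methoxycarbonyl)cyclopent-1-en-1-yl in place of 2-(methoxycarbonyl)-1H-pyrrol-1-yl on an aromatic carbon. Among the measured compounds shown here, no measured pair in the set shares this exact change, so the direction can only be guessed from what the three numbers show. Compound 3 carries a non-aromatic carbocycle bearing the methoxycarbonyl group and gives 54 nM, a lower number than compound 2; on that basis a modest step toward a lower number is expected from compound 2 to compound 4, of about a 1.9-fold lower number from compound 2 to compound 4 (0.28 log units; within the scatter), which may still fall within the scatter. For compound 4 the estimate is 130 nM, with a range from 35 nM to 500 nM.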

Compound 4, inhibition constant: 126 nM
The estimate for compound 4 lay 1.0-fold (0.01 log units) above the measured number; the measured number falls inside the stated range.
By their numbers in this assay, from the lowest: compound 3; then compounds 4 and 2 (each within the scatter of the next); then compound 1.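

In this assay, the series now has its first comparison of compounds that differ in one place: 2-(methoxycarbonyl)cyclopent-1-en-1-yl in place of 2-(methoxycarbonyl)-1H-pyrrol-1-yl gives a 2.0-fold lower number from compound 2 to compound 4 (0.30 log units; within the scatter). At this position, para to a large group, a five-membered aromatic ring with one hetero atom and a five-membered non-aromatic ring of carbon only therefore cannot be told apart on this read-out, even though the count of hydrogen-bond acceptors differs. Nothing available explains this result.

On these data alone, compounds 2 and 4 both carry the methoxycarbonyl group, so what a carboxylic acid or a primary amide would do in its place remains open. Also open, as far as these compounds go, is how a six-membered cyclohexene ring would compare with the five-membered ring of compound 4.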